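Methoxy for methyl on the anilide of a pyridinone amide

The source may hold more compounds than are shown below. What is called first, only, known or untested is meant among the compounds shown, and "the series" means these compounds.

Three compounds sharing one core have been run in a functional assay on the whole organism for inhibition, with Rattus norvegicus as the target, read by cytopathic effect and paw edema, at a dose of 100 mg/kg by the oral route; on this read-out lower numbers stand for less inhibition and higher numbers for more inhibition at the one dose given (going by the name of the read-out). Compound 1 `O=C(NCc1ccccc1)c1c(O)c2cccnc2n(-c2ccccc2)c1=O` carries a benzyl group on its amide nitrogen, and in this assay compound 1 gives 11.3%, the largest of the three numbers shown. Compound 2 `O=C(NC1CCN(Cc2ccccc2)CC1)c1c(O)c2cccnc2n(-c2ccccc2)c1=O`, which bears a larger amine-derived substituent, gives 1.2% in this assay, a gap from compound 1 that lies beyond the scatter. Compound 3 `Cc1ccc(NC(=O)c2c(O)c3cccnc3n(-c3ccccc3)c2=O)cc1` gives 2.2% in this assay, and the step of a number 9.1 percentage points lower from compound 1 to compound 3 (within the scatter) stays within the scatter.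

The compound now in question is compound 4 `COc1ccc(NC(=O)c2c(O)c3cccnc3n(-c3ccccc3)c2=O)cc1`. Relative to compound 1 the change is 4-methoxyphenyl in place of benzyl on an amide-type nitrogen. Going by the values given here, only one measured step bears directly on this: the move to compound 3 also replaced benzyl with an aryl group on the same nitrogen, and that step, a number 9.1 percentage points lower from compound 1 to compound 3 (within the scatter), was within the scatter. Since 4-methoxyphenyl enters where 4-methylphenyl entered before, the account expects a step of roughly that size and in the same downward direction, again not clearly beyond the scatter. The expected step is a number 7.8 percentage points lower from compound 1 to compound 4 (within the scatter). On that basis compound 4 is estimated at 3.5% in this assay, within a range from 0% to 14%.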

Compound 4, a percentage reported as inhibition, in the whole organism at one dose (the size of the read-out at that dose, not a potency): -1.9%
The estimate for compound 4 lay 5.4 percentage points above the measured number, outside the stated range (below it).
By their numbers in this assay, from the lowest: compounds 4, 2, 3 and 1 (each within the scatter of the next, the first and the last beyond it).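

In this assay, putting 4-methoxyphenyl in place of benzyl on the amide-type nitrogen gives a number 13.2 percentage points lower from compound 1 to compound 4 (beyond the scatter), so this exchange of benzyl for a substituted phenyl clears the scatter, whereas the 4-methylphenyl exchange, a number 9.1 percentage points lower from compound 1 to compound 3 (within the scatter), did not. Methoxy in place of methyl on the aromatic carbon gives a number 4.1 percentage points lower from compound 3 to compound 4 (within the scatter), so compound 3 and compound 4 cannot be told apart in this assay, and the substituent at that place on the phenyl ring shows no resolved effect between these two groups. Nothing on hand explains why the benzyl-to-4-methoxyphenyl step comes out as it does.

The compounds shown leave open whether any other group on that aromatic carbon, such as a carboxylic acid, a dimethylamino group or chlorine, would separate from methyl and methoxy in this assay. They also leave open whether a longer chain on the amide-type nitrogen, such as phenethyl, would give a number that stands clear of that of compound 1 at 11.3%, since a single dose gives the size of the read-out and not a potency.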